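The source may hold more compounds than are shown below. What is called first, only, known or untested is meant among the compounds shown, and "the series" means these compounds.

Compound 1 `O=C1CCC(=O)N1C[C@H]1CN(c2ccc(-n3cc(-c4ccccn4)cn3)c(F)c2)C(=O)O1` and compound 2 `O=C1CSC(=O)N1C[C@H]1CN(c2ccc(-n3cc(-c4ccccn4)cn3)c(F)c2)C(=O)O1` share one core and differ only at the chain carbon bound to a saturated ring carbon. In an ADME assay on L02 cells (Homo sapiens) for cytotoxicity, read by MTT assay, with a stated time of 48 h (a higher number here means a weaker inhibitor, a lower number a stronger inhibitor), compound 1 gives > 400 ug/mL, which is a limit of the assay and not a number. In this assay compound 2 gives > 400 ug/mL, again a limit of the assay rather than a number. The step that the two limits leave unreadable from compound 1 to compound 2 therefore cannot be sized. Compound 2 thus stands at the limit of > 400 ug/mL in this assay, at which 2 of the 2 values shown sit, with no numerical value that would place it inside the measured range.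

Compound 3 `CC(=O)OC[C@H]1CN(c2ccc(-n3cc(-c4ccccn4)cn3)c(F)c2)C(=O)O1` is not yet measured. It differs from compound 2 by acetoxy in place of 2,4-dioxo-1,3-thiazolidin-3-yl on a saturated chain carbon bound to a saturated ring carbon. Among the measured compounds shown here, the only measured step that bears on this change is a step that the two limits leave unreadable from compound 1 to compound 2, and it is unreadable, so no sized expectation can be drawn from it; both measured compounds sit at the same limit. On that basis the expected step that the limit leaves unreadable from compound 2 to compound 3 is none beyond the scatter in this assay, and the result for compound 3 is most likely again reported as a limit. Compound 3 is estimated at 500 ug/mL, in the range 250 ug/mL to 2000 ug/mL.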

Compound 3, half-maximal inhibitory concentration: > 400 ug/mL
Compound 3: a limit, no number; the forecaster's own chance of this, stated with the estimate: 85%; the middle value lies beyond the limit too.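

In this assay, compound 3 sits at the same limit of the assay as compound 1 and compound 2, so no step among these three compounds can be read: the limit of > 400 ug/mL in this assay, at which 3 of the 3 values shown sit.

The compounds shown leave open whether 2,5-dioxopyrrolidin-1-yl, 2,4-dioxo-1,3-thiazolidin-3-yl and acetoxy differ at all in this assay, where none of them has a numerical value.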